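The source may report more compounds than this note shows. Statements on the series, on what has been measured and on what is new or still open speak of the compounds shown alone.

Compound 2 `Cc1nc(C(NC(=O)C(=O)Nc2ccc(F)c(F)c2)C2CCCCN2)sc1CO` has been examined in an ADME assay on TZM-b1 cells (Homo sapiens) for cytotoxicity, read by XTT assay, with a stated time of 3 days; on this read-out higher numbers stand for lower toxicity in this test and lower numbers for higher toxicity in this test. In this assay compound 2 gives > 87000 nM, which is a limit of the test rather than a measured number. Its closest neighbour, compound 1 `Cc1ccc(NC(=O)C(=O)NC(c2nc(C)c(CO)s2)C2CCCCN2)cc1F`, differs from it by a fluoro in place of methyl on an aromatic carbon. In this assay compound 1 gives > 88000 nM, which is again a limit. The step that the two limits leave unreadable from compound 1 to compound 2 therefore cannot be read, since both values sit at limits, namely the limit of > 87000 nM in this assay, at which 1 of the 2 values shown sits, and (the limit of > 88000 nM in this assay, at which 1 of the 2 values shown sits). Compound 3 `Cc1nc(C(NC(=O)C(=O)Nc2ccc(F)cc2)C2CCCCN2)sc1CO` is not yet measured; it differs from compound 2 by hydrogen in place of fluoro on an aromatic carbon, a hydrogen in place of fluoro on an aromatic carbon. Among the measured compounds shown here, the only measured step that bears on this change is unreadable, so it gives no direction. Compound 3 is expected to show a step that the limit leaves unreadable from compound 2 to compound 3, most likely again ending at the limit. Compound 3 is estimated at 90000 nM, with a range from 60000 nM to 150000 nM.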

Compound 3, half-maximal cytotoxic concentration: > 90000 nM
Compound 3: only a limit was reported (the forecaster's own chance of this, stated with the estimate: 80%); the middle value lies on the limit itself.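

Among the compounds shown here, compound 1, compound 2 and compound 3 all give limits rather than measured numbers in this assay, so no step among them can be read. The compounds shown leave open at what concentration any of them would become toxic in this assay.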